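The source may report more compounds than this note shows. Statements on the series, on what has been measured and on what is new or still open speak of the compounds shown alone.

Working notes on the series. Compound 1 `CC(C)(C)[Si](C)(C)O[C@@H]1CCCO[C@@H]1CO` carries hydroxymethyl on a saturated ring carbon, while compound 2 `CC(C)(C)[Si](C)(C)O[C@@H]1CCCO[C@@H]1/C=C\C(=O)OCc1ccccc1` and compound 3 `COC(=O)/C=C\[C@H]1OCCC[C@H]1O[Si](C)(C)C(C)(C)C` carry unsaturated esters there. In a functional assay on SW1573 cells (Homo sapiens) for antiproliferative activity, read by sulforhodamine B assay, with a stated time of 48 h (a higher number here means a weaker inhibitor of growth, a lower number a stronger inhibitor of growth), compound 1 gives > 100000 nM as a limit of the assay and not as a number. Compound 2 gives 26000 nM and compound 3 gives 6300 nM as the lowest number of the set, with compound 2 its nearest neighbour.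

The change to compound 4 `CC(C)(C)[Si](C)(C)O[C@@H]1CCCO[C@@H]1/C=C\CO` is hydroxymethyl in place of methoxycarbonyl on a double-bonded chain carbon bound to a double-bonded chain carbon. For the measured compounds named here, two measured steps bear on it, and neither is the same change. The step of an at least 15-fold lower number from compound 1 to compound 3 (1.20 log units; beyond the scatter) is large, and its size rests on a limit. It replaces hydroxymethyl on a saturated ring carbon with the whole 2-(methoxycarbonyl)ethenyl. The step of a 4.1-fold lower number from compound 2 to compound 3 (0.62 log units; beyond the scatter) is modest and alters the ester alone. Compound 4 keeps the double bond but loses the ester, so a higher number is expected in this assay, of modest to large size. The expected step is a 3.2-fold higher number from compound 3 to compound 4 (0.50 log units; beyond the scatter) as an estimate beyond the scatter. For compound 4 the estimated value is 20000 nM with an expected range from 7000 nM to 80000 nM in these cells.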

Compound 4, concentration for 50% growth inhibition: > 100000 nM
Compound 4: only a limit was reported (the forecaster's own chance of this, stated with the estimate: 15%); at least 5.0-fold (0.69 log units) between middle value and limit.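

Replacing methoxycarbonyl with hydroxymethyl on a double-bonded chain carbon bound to a double-bonded chain carbon gives an at least 15-fold higher number from compound 3 to compound 4 (1.20 log units; beyond the scatter) in this assay, so the double bond kept in compound 4 is not enough on its own to retain the growth inhibition seen with compound 3. The earlier change from hydroxymethyl on a saturated ring carbon to the whole 2-(methoxycarbonyl)ethenyl introduced the double bond and the ester together, whereas this change separates them and ties the loss to the exchange at the ester end of the group. The step from compound 1 to compound 4 cannot be read, and no order can be given for the pair, since both values are limits of the assay: the limit of > 100000 nM in this assay, at which 2 of the 4 values shown sit.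

Still open, on these data alone, is whether an amide or a carboxylic acid in place of methoxycarbonyl would hold the number of compound 3, or whether the effect is specific to the esters. Also open, as far as these compounds go, is whether a saturated chain carrying the same methyl ester would act like compound 3, which would show whether the double bond contributes at all.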